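The source may hold more compounds than are shown below. What is called first, only, known or untested is meant among the compounds shown, and "the series" means these compounds.

Measured so far in a physicochemical assay for lipophilicity; on this read-out lower numbers stand for lower lipophilicity and higher numbers for higher lipophilicity:
- compound 1 `COCCCn1c(=O)[nH]c2c(N)nc(C(F)(F)F)cc21` gives 1.9
- compound 2 `Nc1nc(C(F)(F)F)cc2c1[nH]c(=O)n2CC1CCCOC1` gives 2
- compound 3 `Cc1ccc(Cn2c(=O)[nH]c3c(N)nc(C(F)(F)F)cc32)nn1` gives 1.1

Compound 1 sits second highest of the three numbers. Its nearest neighbour is compound 2, with a number 0.10 log units higher from compound 1 to compound 2 (within the scatter), so the two cannot be told apart. The furthest is compound 3, with a number 0.80 log units lower from compound 1 to compound 3 (beyond the scatter); the companion step a number 0.90 log units lower from compound 2 to compound 3 (beyond the scatter) points the same way.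

Compound 4 `Cc1ncc(Cn2c(=O)[nH]c3c(N)nc(C(F)(F)F)cc32)cn1` is the next candidate. Relative to compound 1 the change is 2-methylpyrimidin-5-yl in place of 2-methoxyethyl on a saturated chain carbon bound to an aromatic nitrogen. Within the data shown here, the closest precedent is the step from compound 1 to compound 3, where a six-membered aromatic ring with two hetero atoms and a methyl also replaced the 2-methoxyethyl chain and gave a number 0.80 log units lower from compound 1 to compound 3 (beyond the scatter); the step from compound 2 to compound 3, a number 0.90 log units lower from compound 2 to compound 3 (beyond the scatter), is of the same kind and size. A downward step of modest size in this assay is therefore expected for compound 4, roughly a number 0.70 log units lower from compound 1 to compound 4 (beyond the scatter). Compound 4 is estimated at 1.2, with a range of 0.7 to 1.7.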

Compound 4, distribution coefficient: 1.6
Estimate against measurement, compound 4: 0.40 log units below; the range from low to high includes it.
By their numbers in this assay, from the lowest: compound 3; then compounds 4, 1 and 2 (each within the scatter of the next, the first and the last beyond it).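

At this position, on a saturated chain carbon bound to an aromatic nitrogen, a six-membered aromatic ring with 2 hetero atoms does not by itself set the number in this assay: exchanging one methyl-bearing ring of this kind for the other gives a number 0.50 log units higher from compound 3 to compound 4 (beyond the scatter) and the two are told apart. Replacing 2-methoxyethyl with 2-methylpyrimidin-5-yl gives a number 0.30 log units lower from compound 1 to compound 4 (within the scatter) and leaves no readable change, so the earlier drop with 6-methylpyridazin-3-yl does not extend to every such ring. The comparison with oxan-3-yl, a number 0.40 log units lower from compound 2 to compound 4 (beyond the scatter), is nevertheless readable.

From the compounds shown here alone, it remains open whether the gap between the two rings persists without their methyl groups. Going by these compounds, how a plain phenyl ring, an amine or a carboxylic acid would read at this position also remains open.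

No measurement available here accounts for the difference between the two rings.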